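Sulfonyl Aryl Exchange on a Trimethoxyphenyl Sulfonamide Series

The source may hold more compounds than are shown below. What is called first, only, known or untested is meant among the compounds shown, and "the series" means these compounds.

Three compounds have been measured in a functional assay on PC-3 cells (Homo sapiens) for inhibition, read by MTT assay, with a stated time of 48 h; a lower number here means a stronger inhibitor, a higher number a weaker inhibitor:
compound 1, `COc1cc(N(Cc2cccc(C)c2)S(=O)(=O)c2ccc(C)cc2)cc(OC)c1OC`: 8580 nM
compound 2, `COc1cc(N(Cc2ccccc2)S(=O)(=O)c2ccc(C)cc2)cc(OC)c1OC`: 7810 nM
compound 3, `COc1cc(N(Cc2nc3ccccc3[nH]2)S(=O)(=O)c2ccc(F)cc2)cc(OC)c1OC`: 7990 nM

Compound 3 holds the second highest of the three numbers, but all three lie within the scatter of one another; the values of compound 2 and compound 3 show no separation. Among the compounds with values here, the one step between neighbours, a 1.1-fold lower number from compound 1 to compound 2 (0.04 log units; within the scatter), is also within the scatter.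

Compound 4, `COc1ccc(S(=O)(=O)N(Cc2nc3ccccc3[nH]2)c2cc(OC)c(OC)c(OC)c2)cc1OC`, differs from compound 3 by 3,4-dimethoxyphenyl in place of 4-fluorophenyl on a sulfonyl sulfur. Within the data shown here, no measured step touches the group on the sulfonyl sulfur, and compounds 1, 2 and 3, which differ at two places, give numbers that do not separate. The step of a 1.0-fold higher number from compound 3 to compound 4 (0.00 log units; within the scatter) is therefore expected to stay within the scatter. Compound 4 is estimated at 8000 nM, in the range 3000 nM to 22000 nM.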

Compound 4, half-maximal inhibitory concentration: 30400 nM
Beside the measured number, compound 4's estimate is 3.8-fold (0.58 log units) below it; measured number outside the range, above it.
By their numbers in this assay, from the lowest: compounds 2, 3 and 1 (each within the scatter of the next); then compound 4.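

Within the data shown here, the group on the sulfonyl sulfur is the first place where a single change goes beyond the scatter: in this assay, 3,4-dimethoxyphenyl in place of 4-fluorophenyl gives a 3.8-fold higher number from compound 3 to compound 4 (0.58 log units; beyond the scatter) as a modest weakening. Among these compounds, the only earlier step, a 1.1-fold lower number from compound 1 to compound 2 (0.04 log units; within the scatter) at another place, stayed within the scatter. Nothing at hand explains this result.

As far as these compounds go, it remains open whether the weakening comes from the two methoxy groups together, from one of them, or from the loss of fluorine. An unsubstituted phenyl, a single methoxy group or an amine on that ring could separate these readings.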